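The source may hold more compounds than are shown below. What is called first, only, known or untested is meant among the compounds shown, and "the series" means these compounds.

Compound 3 `CC(C)(C)c1ccc(C(=O)N2CCC3(CC2)C(=O)N(CC(=O)N2CCCC(O)C2)CN3c2ccccc2)cc1` gives the highest of the three numbers in an assay on HEK293 cells for displacement of a labelled ligand from NPC1-like intracellular cholesterol transporter 1 (Homo sapiens) (a higher number here means a weaker inhibitor, a lower number a stronger inhibitor), at 12200 nM. Compound 2 `CC1CCCN(C(=O)CN2CN(c3ccccc3)C3(CCN(C(=O)c4ccc(C(C)(C)C)cc4)CC3)C2=O)C1` gives 12000 nM, and the step of a 1.0-fold higher number from compound 2 to compound 3 (0.01 log units; within the scatter) lies within the scatter. Compound 1 `CC(C)(C)c1ccc(C(=O)N2CCC3(CC2)C(=O)N(CC(=O)NCCO)CN3c2ccccc2)cc1` gives 1000 nM, so the step of a 12-fold higher number from compound 1 to compound 3 (1.09 log units; beyond the scatter) is beyond the scatter. Compound 4 `CC(C)(C)c1ccc(C(=O)N2CCC3(CC2)C(=O)N(CC(=O)NCCCNS(C)(=O)=O)CN3c2ccccc2)cc1` is not yet measured; the change is (3-(methanesulfonamido)propyl)amino in place of 3-hydroxypiperidin-1-yl on a carbonyl carbon. Going by the values given here, the steps that bear on it are a 12-fold higher number from compound 1 to compound 3 (1.09 log units; beyond the scatter) and a 12-fold higher number from compound 1 to compound 2 (1.08 log units; beyond the scatter), both from an open-chain amino to a piperidinyl, both large. Compound 4 returns to an open-chain amino. The expected step is therefore an 8.1-fold lower number from compound 3 to compound 4 (0.91 log units; beyond the scatter), a lower number. Compound 4 is estimated at 1500 nM, in the range 500 nM to 5000 nM.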

Compound 4, half-maximal inhibitory concentration: 10400 nM
Compound 4: middle estimate off by 6.9-fold (0.84 log units), on the low side; the measured number lies above the stated range.
By their numbers in this assay, from the lowest: compound 1; then compounds 4, 2 and 3 (each within the scatter of the next).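

An open-chain amino on this carbonyl carbon is not enough for the lower number: a 1.2-fold lower number from compound 3 to compound 4 (0.07 log units; within the scatter) and a 1.2-fold lower number from compound 2 to compound 4 (0.06 log units; within the scatter), whereas a 10-fold higher number from compound 1 to compound 4 (1.02 log units; beyond the scatter). Among these four, the (2-hydroxyethyl)amino of compound 1 alone stands apart, and compound 4, despite its open chain, sits with the piperidinyl amides compound 2 and compound 3. Nothing measured here gives a reason for this.

Still open, on these data alone, is whether compound 1 owes its number to the terminal hydroxy or to the chain length. A (3-hydroxypropyl)amino or (2-methoxyethyl)amino group on the same carbonyl carbon would help separate the two.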